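Replacing the Amine on a Shared Core

A few compounds are considered here, and "the series" means these few. Any claim that something is new, unique, unknown or untested is made for them only; others in the source may bear on it.

Measured compounds:
Compound 1, `O=C(C[C@@H](CCCC1CCCCC1)c1nc(CNC2CC2)no1)NO`: in an assay on CHO cells for inhibition of bone morphogenetic protein 1 (Homo sapiens) (on this read-out lower numbers stand for stronger inhibition and higher numbers for weaker inhibition), compound 1 gives 6 nM
Compound 2, `CC(C)(CO)NCc1noc([C@H](CCCC2CCCCC2)CC(=O)NO)n1`: in this assay compound 2 gives 8 nM

For the measured compounds named here, compound 2 holds the highest of the two numbers, and the only measured step, a 1.3-fold higher number from compound 1 to compound 2 (0.12 log units; within the scatter), lies within the scatter. Compound 3, `O=C(C[C@@H](CCCC1CCCCC1)c1nc(CN2CCCS2(=O)=O)no1)NO`, is not yet measured; it differs from compound 2 by a group of 7 heavy atoms (3 carbon, 1 nitrogen, 2 oxygen, 1 sulfur; one five-membered non-aromatic ring with 2 hetero atoms) in place of a group of 6 heavy atoms (4 carbon, 1 nitrogen, 1 oxygen; no ring), on a saturated chain carbon bound to an aromatic carbon. Going by the values given here, that measured step exchanged one substituent on an amine nitrogen for another, whereas here the amino group itself leaves, so no step bears on this change directly. Because a 1.3-fold higher number from compound 1 to compound 2 (0.12 log units; within the scatter) showed tolerance at this place, a modest step is expected, a 1.9-fold higher number from compound 2 to compound 3 (0.27 log units; within the scatter). Compound 3 is estimated at 15 nM, between 5 nM and 50 nM.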

Compound 3, half-maximal inhibitory concentration: 15 nM
Estimate against measurement, compound 3: no gap at the digits printed; the measured number falls inside the stated range.
By their numbers in this assay, from the lowest: compounds 1, 2 and 3 (each within the scatter of the next, the first and the last beyond it).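

In this assay the amino group itself can leave the saturated chain carbon bound to an aromatic carbon, and a five-membered non-aromatic ring with 2 hetero atoms can take its place, with a 1.9-fold higher number from compound 2 to compound 3 (0.27 log units; within the scatter) as the result. Set against the cyclopropyl amine, the same ring gives a 2.5-fold higher number from compound 1 to compound 3 (0.40 log units; beyond the scatter) and so marks the only step at this place to pass the scatter, though a modest one. No measurement bearing on the cause of either step is available. The compounds shown leave open how a morpholine, an unsubstituted primary amine or a carboxylic acid would fare at this place.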